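The source may report more compounds than this note shows. Statements on the series, on what has been measured and on what is new or still open speak of the compounds shown alone.

Working notes on the series. In a functional assay on the whole organism (strain Sprague-Dawley) for inhibition, with Rattus norvegicus as the target (on this read-out lower numbers stand for an effect already at smaller amounts and higher numbers for an effect only at larger amounts of compound), compound 1 `O=c1c(-c2nn[nH]n2)c[nH]c2ccc(F)cc12` gives > 20 mg/kg, and this value is a limit of the assay, not a number. Compound 2 `Fc1ccc2ncc(-c3nn[nH]n3)cc2c1` belongs to the same series; in this assay compound 2 gives 50 mg/kg. Among the measured compounds shown here, because one of the two values is only a limit, no step between these two compounds can be drawn from them; the pair shows no more than that one reads as a number and the other does not. The standing of compound 1 is thus known only as a range: the limit of > 20 mg/kg in this assay, at which 1 of the 2 values shown sits.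

Compound 3 `Cc1ccc2[nH]cc(-c3nn[nH]n3)c(=O)c2c1` has not yet been measured in this assay. It differs from compound 1 in one place: methyl in place of fluoro on an aromatic carbon. For the measured compounds named here, no step between measured compounds is available to indicate how large a change of this kind runs, so no direction beyond the scatter is assumed for it. The step is expected to stay small, a step that the limit leaves unreadable from compound 1 to compound 3. For compound 3 in this assay the estimate is 30 mg/kg, with a range from 10 mg/kg to 100 mg/kg, and a further limit in place of a number remains a real possibility.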

Compound 3, minimum effective dose: > 25 mg/kg
Compound 3: no number, only a limit; the forecaster's own chance of this, stated with the estimate: 50%; the middle value does not contradict the limit.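

In this assay compound 3 gives > 25 mg/kg, a limit and not a number. Among the compounds shown here, compound 1 also stands only at a limit, and no step from compound 1 to compound 3 can be read. The compounds shown leave open whether methyl in place of fluoro on an aromatic carbon changes the minimum effective dose at all, and in which direction.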